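This account rests on a few compounds, and the source may have more. Where it says the series, first, only, none or still open, it means among the compounds named here.

Compound 1 `CC(C)=CCOc1cc(Nc2nccs2)ccc1Cl`: 26000 nM
Compound 2 `Clc1ccc(Nc2nccs2)cc1OCc1nccs1`: 20000 nM
Compound 3 `CC/C(C)=C\COc1cc(Nc2nccs2)ccc1Cl`: not yet measured

Both values come from a functional assay on MT2 cells (Homo sapiens) for cytotoxicity, read by MTT assay; on this read-out higher numbers stand for lower toxicity in this test and lower numbers for higher toxicity in this test. In this assay, compound 2 gives 20000 nM, which cannot be told apart from the value of compound 1. Within the data shown here, the only measured step is a 1.3-fold lower number from compound 1 to compound 2 (0.11 log units; within the scatter). Placing 1,3-thiazol-2-yl where compound 1 has 2-methylprop-1-en-1-yl therefore left the number unchanged within the scatter.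

Compound 3 differs from compound 2 in one place: 2-methylbut-1-en-1-yl in place of 1,3-thiazol-2-yl on a saturated chain carbon bound to an oxygen on an aromatic ring. It has 2-methylbut-1-en-1-yl in place of 1,3-thiazol-2-yl on a saturated chain carbon bound to an oxygen on an aromatic ring. The measured step bears directly on this change. It swaps the same 1,3-thiazol-2-yl against a similarly named open chain, and its size stayed within the scatter. Two compounds are thin evidence, but compound 1, with the nearest group to the incoming one, gives 26000 nM, so no step beyond the scatter is expected. The expected change is a 1.2-fold higher number from compound 2 to compound 3 (0.06 log units; within the scatter). For compound 3 the estimated value is 23000 nM, with an expected range from 11000 nM to 45000 nM.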

Compound 3, half-maximal cytotoxic concentration: 18000 nM
Beside the measured number, compound 3's estimate is 1.3-fold (0.11 log units) above it, within the range that was stated.
By their numbers in this assay, from the lowest: compounds 3, 2 and 1 (each within the scatter of the next).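

In this assay, placing 2-methylbut-1-en-1-yl where compound 2 has 1,3-thiazol-2-yl gives a 1.1-fold lower number from compound 2 to compound 3 (0.05 log units; within the scatter). A five-membered aromatic ring with 2 hydrogen-bond acceptors and an open chain with none therefore cannot be told apart at this position, on a saturated chain carbon bound to an oxygen on an aromatic ring, even though the earlier step had already hinted at this. The other new step, methyl in place of hydrogen on a saturated chain carbon bound to a double-bonded chain carbon, gives a 1.4-fold lower number from compound 1 to compound 3 (0.16 log units; within the scatter), so this small addition to the open chain also leaves the number unchanged within the scatter, and nothing measured here offers an explanation for this lack of difference.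

The compounds shown leave open whether an amine, a carboxylic acid or a much longer chain in this place would move the number beyond the scatter. Only this one read-out is shown, so how these three compounds compare in any other test remains unknown.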